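The source may hold more compounds than are shown below. What is called first, only, known or untested is meant among the compounds shown, and "the series" means these compounds.

Three compounds have so far been measured in a functional assay on HT-29 cells (Homo sapiens) for inhibition, read by luminescence and CellTiter-Glo, with a stated time of 24 h (a lower number here means that less compound is needed, a higher number that more compound is needed for the effect), and give these values:

Compound 1 `CN1C(=S)[C@@H](NC(=O)c2nc(Cc3ccccc3)n(C)n2)COc2ccccc21` gives 2.5 nM in this assay
Compound 2 `CN1C(=S)[C@@H](NC(=O)c2nc(Cc3ccccc3)n(CCC(F)(F)F)n2)COc2ccccc21` gives 1550 nM in this assay
Compound 3 `CN1C(=S)[C@@H](NC(=O)c2nc(Cc3ccccc3)n(CCCC#N)n2)COc2ccccc21` gives 2400 nM in this assay

Compound 3 carries a 3-cyanopropyl group on an aromatic nitrogen. It stands level with compound 2, since a 1.5-fold higher number from compound 2 to compound 3 (0.19 log units; within the scatter) is within the scatter. Both lie far from compound 1, with a 620-fold higher number from compound 1 to compound 2 (2.79 log units; beyond the scatter) and a 960-fold higher number from compound 1 to compound 3 (2.98 log units; beyond the scatter) as large steps beyond the scatter.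

Compound 4 `CN1C(=S)[C@@H](NC(=O)c2nc(Cc3ccccc3)n(C3COC3)n2)COc2ccccc21` makes a single change, (oxetan-3-yl in place of 3-cyanopropyl on an aromatic nitrogen), so that oxetan-3-yl stands in place of 3-cyanopropyl on an aromatic nitrogen. Among the compounds with values here, no measured step places a ring there, so the evidence is indirect. The two large steps show that the number in this assay can move widely with the group at this nitrogen. Within the data shown here, the gap between compound 2 and compound 3 shows only that those two groups are not separated. Compound 1 marks how much room there is, through a 960-fold higher number from compound 1 to compound 3 (2.98 log units; beyond the scatter), and a partial return towards it is expected rather than a full one. The expected move is a 12-fold lower number from compound 3 to compound 4 (1.08 log units; beyond the scatter), a sizeable step towards a lower number. Compound 4 is estimated at 200 nM, with an expected range from 20 nM to 1500 nM.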

Compound 4, half-maximal effective concentration: 916 nM
Estimate against measurement, compound 4: 4.6-fold (0.66 log units) below; the measured number falls inside the stated range.
By their numbers in this assay, from the lowest: compound 1; then compounds 4, 2 and 3 (each within the scatter of the next, the first and the last beyond it).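

In this assay, oxetan-3-yl brings the first ring to this aromatic nitrogen, and its exchange for 3-cyanopropyl produces a real but modest change, with a 2.6-fold lower number from compound 3 to compound 4 (0.42 log units; beyond the scatter). Against 3,3,3-trifluoropropyl the same ring cannot be separated, with a 1.7-fold lower number from compound 2 to compound 4 (0.23 log units; within the scatter), so the four-membered ring with its oxygen falls in the same broad range as these two open chains and forms no class apart from them. The gap to methyl stays large, with a 370-fold higher number from compound 1 to compound 4 (2.56 log units; beyond the scatter), which shows that the ring recovers only a small part of what the two chains lost and that, among the four groups shown, methyl alone gives a number in the low range.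

No evidence is available that bears on why these groups differ in this way. From the compounds shown here alone, what ethyl or cyclopropyl would give at this nitrogen remains open, and with it whether the number already rises steeply with a single added carbon or only with a group as large as those in compounds 2, 3 and 4.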